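Extending the Ethyl Arm of Compound 1 with a Hydroxyl

The compounds below may be only part of what the source reports. "The series", "measured", "known", "first", "only" and "open" are said of these compounds alone.

Measured compounds:
compound 1, `CCN(Cc1ccccc1)c1cccc(C(=O)N2CCc3ccc(OS(N)(=O)=O)cc3C2)c1`, 69%
compound 2, `NS(=O)(=O)Oc1ccc2c(c1)CN(C(=O)c1cccc(N3CCCCC3)c1)CC2`, 11.9%
compound 3, `NS(=O)(=O)Oc1ccc2c(c1)CN(C(=O)c1cccc(N3CCc4ccccc4C3)c1)CC2`, 50.2%

All three share one core and differ only in the amine on the aromatic carbon of the benzoyl part. In an assay on HEK293 cells for inhibition of Steryl-sulfatase (Homo sapiens), tested at 1 uM (a higher number here means a stronger effect of the compound at the concentration tested, a lower number a weaker effect), compound 1 gives the highest of the three numbers. Its nearest neighbour is compound 3, with a number 18.8 percentage points lower from compound 1 to compound 3 (beyond the scatter); its furthest is compound 2, with a number 57.1 percentage points lower from compound 1 to compound 2 (beyond the scatter). Between the two cyclic amines, a number 38.3 percentage points higher from compound 2 to compound 3 (beyond the scatter).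

The unmeasured compound 4, `NS(=O)(=O)Oc1ccc2c(c1)CN(C(=O)c1cccc(N(CCCO)Cc3ccccc3)c1)CC2`, keeps the benzyl(ethyl)amino arrangement of compound 1 and changes it only at the chain end: hydroxymethyl in place of hydrogen on a saturated chain carbon, two bonds along the chain from a nitrogen on an aromatic ring.

Within the data shown here, no measured step bears directly on this change. The two steps from compound 1 both swap the whole open amine for a ring, and both lower the number, which marks the open benzyl(ethyl)amino arm as the one that has given the strongest result so far. Compound 4 retains that arm and only lengthens its ethyl to 3-hydroxypropyl, so the expected step is small: a number 9 percentage points lower from compound 1 to compound 4 (within the scatter) is estimated to lie within or only slightly beyond the scatter, more likely downward than upward. In this assay compound 4 is therefore expected to give about 60%, within a range from 40% to 78%.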

Compound 4, a percentage reported as inhibition, at one concentration (the size of the read-out at that concentration, not a potency): 37.3%
For compound 4 the middle estimate is 22.7 percentage points above the measured one; measured number below the stated range.
By their numbers in this assay, from the lowest: compound 2; then compound 4; then compound 3; then compound 1.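

In this assay the step from ethyl to 3-hydroxypropyl gives a number 31.7 percentage points lower from compound 1 to compound 4 (beyond the scatter) and so shows that the number responds to the end of this chain, even with the benzyl group and the nitrogen left as they are in compound 1. The earlier steps shown here from compound 1 replaced the whole benzyl(ethyl)amino group with a ring, so they could not show whether the chain alone mattered; keeping the open amine does not by itself preserve the number of compound 1. No evidence at hand bears on why the number falls.

The change brings added chain length and a hydroxyl in together, and the compounds shown do not separate them: a plain propyl chain on the same nitrogen would test the length alone, while 2-hydroxyethyl would test the hydroxyl on a shorter chain. From the compounds shown here alone, whether a methoxy group, an amine or a carboxylic acid at the end of the 3-carbon chain would give a number like that of the hydroxyl also remains open.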